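Swapping Piperidin-1-yl for Difluorophenyl: Cytotoxicity Outlook

The source may hold more compounds than are shown below. What is called first, only, known or untested is meant among the compounds shown, and "the series" means these compounds.

Compound 1 `C[C@]1(CN2CCc3nc(-c4ccc(F)c(F)c4)oc3C2)Cn2cc([N+](=O)[O-])nc2O1`: > 32 ug/mL
Compound 2 `C[C@]1(CN2CCc3oc(-c4ccc(F)cc4)nc3C2)Cn2cc([N+](=O)[O-])nc2O1`: > 32 ug/mL
Compound 3 `C[C@]1(CN2CCc3nc(N4CCCCC4)ccc3C2)Cn2cc([N+](=O)[O-])nc2O1`: "not determined" (no result reported)

In an ADME assay on Vero cells (Chlorocebus sabaeus) for cytotoxicity, read by MTT assay, with a stated time of 72 h (a lower number here means that less compound is tolerated, a higher number that more compound is tolerated), compound 1 gives > 32 ug/mL, which is a limit of the test rather than a measured number. Compound 2 likewise gives > 32 ug/mL in this assay, again a limit. Compound 3 shows "not determined" (no result reported) in this assay, so it stands on no number of its own; the limit of > 32 ug/mL in this assay, at which 2 of the 3 values shown sit, marks where the other two compounds sit. Compound 4 `C[C@]1(CN2CCc3nc(-c4ccc(F)c(F)c4)ccc3C2)Cn2cc([N+](=O)[O-])nc2O1` differs from compound 3 in one place: 3,4-difluorophenyl in place of piperidin-1-yl on an aromatic carbon. Going by the values given here, no measured step exists for this pair, so only the two limits guide the expectation, and compound 4 is expected to reach the same limit, with no difference beyond the usual scatter. Compound 4 is therefore estimated at 40 ug/mL, with a range from 16 ug/mL to 100 ug/mL.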

Compound 4, half-maximal cytotoxic concentration: > 32 ug/mL
Compound 4 ended at the assay's limit (the forecaster's own chance of this, stated with the estimate: 75%); the middle value lies beyond the limit too.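

No step can be read between compound 3, which has no reported result, and compound 4. In this assay compound 4 gives > 32 ug/mL, which is a limit. The compounds shown leave open where the actual values of compound 1, compound 2 and compound 4 lie: the limit of > 32 ug/mL in this assay, at which 3 of the 4 values shown sit.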